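A few compounds are considered here, and "the series" means these few. Any claim that something is new, unique, unknown or untested is made for them only; others in the source may bear on it.

The compounds share one core, a methacrylamide attached through a double bond to an aromatic ring that carries a second, six-membered ring of carbon only. In a functional assay on HO8910 cells (Homo sapiens) for cytotoxicity, read by CCK-8 assay, with a stated time of 24 h (a higher number here means a weaker inhibitor, a lower number a stronger inhibitor), compound 1 `C/C(=C\c1ccc(-c2ccc(C)cc2)o1)C(N)=O` gives 1660 nM. Compound 3 `C/C(=C\c1cccc(-c2ccccc2)c1)C(N)=O` gives 12600 nM in this assay. Compound 2 `C/C(=C\c1cc(-c2ccc(F)cc2)cs1)C(N)=O` reaches only the limit of this assay, > 50000 nM, so no number is known for it. Among the three values shown, one sits at the limit of > 50000 nM in this assay, at which 1 of the 3 values shown sits. No two of these compounds differ in only one place, so no measured step can be taken as a guide.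

Compound 4 `COc1ccc(-c2csc(/C=C(\C)C(N)=O)c2)cc1` has not yet been measured in this assay. It differs from compound 2 in one place: methoxy in place of fluoro on an aromatic carbon. For the measured compounds named here, with no measured step of this kind to lean on, the change is expected to move the value little, if at all, beyond the scatter. In this assay compound 4 is expected to give 40000 nM, with a range from 8000 nM to 100000 nM. The step from compound 2 to compound 4 is estimated as an at least 1.2-fold lower number from compound 2 to compound 4 (0.09 log units; that floor lies within the scatter).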

Compound 4, half-maximal inhibitory concentration: > 50000 nM
Compound 4 gave a limit, no number; the forecaster's own chance of this, stated with the estimate: 55%; at least 1.2-fold (0.09 log units) between middle value and limit.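

Compound 2 and compound 4 both stand at a limit in this assay, not at a number, so no step can be read between them: the limit of > 50000 nM in this assay, at which 2 of the 4 values shown sit.

The compounds shown leave open whether methoxy in place of fluoro on an aromatic carbon changes the value at all.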